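Adding a Methoxy Group to the Cyclobutyl Ring

The source may hold more compounds than are shown below. What is called first, only, known or untested is meant among the compounds shown, and "the series" means these compounds.

Compound 1, `COc1cc(OC2CCC2)cc(-c2ccc3c(c2)CC[C@H]([C@@H]2C[C@H]2C(=O)O)O3)c1F`, in a functional assay on HEK293 cells for agonist activity at Free fatty acid receptor 1 (Homo sapiens), read by HTRF and inositol phosphate accumulation, with a stated time of 60 min (on this read-out higher numbers stand for an effect only at larger amounts of compound and lower numbers for an effect already at smaller amounts), gives > 10000 nM, which is a limit of the assay and not a number.
Compound 2, `COc1cc(OC2CCC2)cc(-c2ccc3c(c2)CC[C@H](CCC(=O)O)O3)c1F`, in this assay gives > 10000 nM, again a limit.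

Both measured values are limits, so the step that the two limits leave unreadable from compound 1 to compound 2 cannot be read. Compound 1 thus stands at the limit, as the limit of > 10000 nM in this assay, at which 2 of the 2 values shown sit, shows. Compound 3 is `COc1cc(O[C@H]2C[C@H](OC)C2)cc(-c2ccc3c(c2)CC[C@H]([C@@H]2C[C@H]2C(=O)O)O3)c1F`; it differs from compound 1 by methoxy in place of hydrogen on a saturated ring carbon. No readable measured step bears on this change. Compound 3 is expected to stay at the limit, an estimated 10000 nM with a range from 3000 nM to 30000 nM. The expected step of a number no higher from compound 1 to compound 3 (the limit leaves the size open) is none beyond the scatter.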

Compound 3, half-maximal effective concentration: > 10000 nM
Compound 3: no number, only a limit; the forecaster's own chance of this, stated with the estimate: 80%; the middle value sits exactly at the limit.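

Compound 1 and compound 3 both give only a limit in this assay, so no step between them can be read: the limit of > 10000 nM in this assay, at which 3 of the 3 values shown sit.

The compounds shown leave open what methoxy in place of hydrogen on the cyclobutyl ring does to the effect at smaller amounts of compound.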